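The source may hold more compounds than are shown below. What is called first, only, known or untested is meant among the compounds shown, and "the series" means these compounds.

In an ADME assay on L1210/0 cells (Mus musculus) for cytotoxicity, with a stated time of 48 h (on this read-out higher numbers stand for weaker inhibition and lower numbers for stronger inhibition), compound 1 (`CC(O)Cn1cnc2c(N)nc(I)nc21`) gives > 200000 nM, which is a limit of the assay and not a number. Compound 2 (`CC(=O)OC(C)Cn1cnc2c(N)nc(I)nc21`) gives > 200000 nM, also a limit. Compound 3 (`COc1nc(I)nc2c1ncn2COCCO`) gives > 200000 nM, again only a limit. Compound 3 therefore has no exact number and shares its position with the other two, as the record so far shows: the limit of > 200000 nM in this assay, at which 3 of the 3 values shown sit.

Compound 4 (`Nc1nc(I)nc2c1ncn2COCCO`) has amino in place of the methoxy of compound 3, on an aromatic carbon: amino in place of methoxy on an aromatic carbon.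

Going by the values given here, the only measured step is a step that the two limits leave unreadable from compound 1 to compound 2. It involves a different change at a different place, so it gives no size to carry over. Compound 1 also carries amino in that place, and its > 200000 nM is a limit. No step beyond the scatter is therefore expected, and no direction can be favoured. The expected step is a number no higher from compound 3 to compound 4 (the limit leaves the size open). The estimated value for compound 4 is 200000 nM, with an expected range from 70000 nM to 300000 nM.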

Compound 4, half-maximal inhibitory concentration: > 200000 nM
Compound 4: a limit, no number (the forecaster's own chance of this, stated with the estimate: 75%); the middle value lies on the limit itself.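

Compound 4 also gives only a limit of the assay and not a number, so its steps from compound 1, compound 2 and compound 3 cannot be read: the limit of > 200000 nM in this assay, at which 4 of the 4 values shown sit. The compounds shown leave open which change, if any, would bring a measurable value in this assay.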